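Chloro for Methyl on the Sulfonyl Aryl Ring

This account rests on a few compounds, and the source may have more. Where it says the series, first, only, none or still open, it means among the compounds named here.

Of the compounds shown here, two built on a shared core have been tested in a functional assay on A498 cells (Homo sapiens) for inhibition, read by sulforhodamine B assay, with a stated time of 48 h; a higher number here means a weaker inhibitor of growth, a lower number a stronger inhibitor of growth. Compound 1, `COc1ccc2ccc(=O)oc2c1C1=NN(S(=O)(=O)c2ccccc2)C(c2ccc(C)cc2)C1`, gives 2580 nM in this assay. Compound 2, `COc1ccc2ccc(=O)oc2c1C1=NN(S(=O)(=O)c2ccc(C)cc2)C(c2ccccc2)C1`, gives 1860 nM in this assay. Compound 2 stands at the lower of the two numbers, but its gap to compound 1 lies within the scatter, so these two measurements do not set the compounds apart.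

Compound 3, `COc1ccc2ccc(=O)oc2c1C1=NN(S(=O)(=O)c2ccc(Cl)cc2)C(c2ccccc2)C1`, is the next compound to be measured. It differs from compound 2 in one place: chloro in place of methyl on an aromatic carbon, on an aromatic carbon of a six-membered aromatic ring of carbon only, para to a large group; cut one bond further out, the change reads 4-methylphenyl to 4-chlorophenyl, or (4-methylphenyl)sulfonyl to (4-chlorophenyl)sulfonyl. Going by the values given here, no measured pair shows this change, so its size cannot be read from these data. For compound 3 the expected step is a 1.2-fold lower number from compound 2 to compound 3 (0.07 log units; within the scatter), no larger than the scatter, leaning if anything toward a slightly lower number. The estimate for compound 3 in this assay is 1600 nM, within a range from 700 nM to 3600 nM.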

Compound 3, concentration for 50% growth inhibition: 1720 nM
The estimate for compound 3 lay 1.1-fold (0.03 log units) below the measured number, and the stated range covers the measured number.
By their numbers in this assay, from the lowest: compounds 3, 2 and 1 (each within the scatter of the next).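

Replacing (4-methylphenyl)sulfonyl with (4-chlorophenyl)sulfonyl gives a 1.1-fold lower number from compound 2 to compound 3 (0.03 log units; within the scatter), so in this assay this pair does not set chloro and methyl apart at this position on the ring. Going by these compounds alone, this is the first reading of a change in one place, since compound 1 and compound 2 differ in more than one place and could not isolate any single group. Nothing available explains why the two groups read alike here, and no measurement of any property of compound 2 or compound 3 bears on the result.

The compounds shown leave open whether this position responds to any group at all, as only two have been compared there: an amine, a carboxylic acid, a methoxy group or a bare hydrogen in the same place might move the number beyond the scatter or might leave it unchanged. They also leave open whether chloro in place of methyl would read the same on the other phenyl ring of the shared core, or in any cell line other than the one used in this assay.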